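Acetyl in place of aryl carbonyl on a shared core

The compounds below may be only part of what the source reports. "The series", "measured", "known", "first", "only" and "open" are said of these compounds alone.

Compound 1 `CS(=O)(=O)NC1CCC(CN2CCN(c3cc(=O)c4cc(C(F)(F)F)cc([N+](=O)[O-])c4s3)CC2)CC1`: 105%
Compound 2 `O=C(OC1CCC(CN2CCN(c3cc(=O)c4cc(C(F)(F)F)cc([N+](=O)[O-])c4s3)CC2)CC1)c1ccc(F)cc1`: 3%
Compound 3 `O=C(OC1CCC(CN2CCN(c3cc(=O)c4cc(C(F)(F)F)cc([N+](=O)[O-])c4s3)CC2)CC1)c1ccc(C(F)(F)F)cc1`: 5.2%

In an ADME assay on cells (Hepatocyte, Homo sapiens) for metabolic stability, with a stated time of 30 min (on this read-out lower numbers stand for a less stable compound and higher numbers for a more stable compound), compound 1 gives 105%, compound 2 gives 3% and compound 3 gives 5.2%. Compound 3 therefore stands second highest of the three, close to compound 2 and far from compound 1. Among the compounds with values here, the one large step seen so far is a number 102 percentage points lower from compound 1 to compound 2 (beyond the scatter), while the step of a number 2.2 percentage points higher from compound 2 to compound 3 (within the scatter) is within the scatter.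

Compound 4 `CC(=O)OC1CCC(CN2CCN(c3cc(=O)c4cc(C(F)(F)F)cc([N+](=O)[O-])c4s3)CC2)CC1` keeps the shared core and differs from compound 3 in one place: methyl in place of 4-(trifluoromethyl)phenyl on a carbonyl carbon. The change sits on the carbonyl carbon whose other neighbour is the oxygen next to the carbonyl group. Within the data shown here, no measured step exchanges a group at that carbon; the only step that touches this region, from compound 2 to compound 3, alters the 4-substituent of the phenyl ring and stays within the scatter. The step from compound 1 to compound 2 shows that what hangs on the saturated ring carbon matters strongly, but does not say whether methyl behaves like the phenyl groups.

Compound 4 is expected to give 15%, in a range from 3% to 55%, which means an expected step of a number 9.8 percentage points higher from compound 3 to compound 4 (within the scatter), upward but uncertain in size.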

Compound 4, percent of the compound remaining: 0%
The estimate for compound 4 lay 15 percentage points above the measured number; measured number below the stated range.
By their numbers in this assay, from the lowest: compounds 4, 2 and 3 (each within the scatter of the next); then compound 1.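

In this assay, methyl on the carbonyl carbon gives a number 5.2 percentage points lower from compound 3 to compound 4 (within the scatter), and in place of 4-fluorophenyl it gives a number 3 percentage points lower from compound 2 to compound 4 (within the scatter), so exchanging the whole aromatic ring for methyl at this position, and not only the substituent on that ring, leaves the read-out within the scatter. The acetoxy group on the saturated ring carbon also gives a number 105 percentage points lower from compound 1 to compound 4 (beyond the scatter), which shows that the large gap from compound 1 does not depend on an aryl group being present: among these four compounds, all three carrying a carbonyloxy group on that carbon lie far from the methanesulfonamido compound, and none goes against this. Nothing available here accounts for this pattern.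

The compounds shown leave open whether the low numbers go with the oxygen attached to the saturated ring carbon or with the carbonyl group on it. An acetamido group or a free hydroxyl on that carbon would separate these two readings, and either could be compared directly with compound 4.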